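The compounds below may be only part of what the source reports. "The series", "measured", "known", "first", "only" and "open" are said of these compounds alone.

Among the compounds with values here, compound 2 `CC(=O)c1ccc(NC(=O)/C=C/C(=O)N2C/C(=C\c3ccccc3)C(=O)/C(=C/c3ccccc3)C2)cc1` gives 5500 nM in a functional assay on L1210 cells (Mus musculus) for cytotoxicity (a lower number here means a stronger inhibitor, a higher number a weaker inhibitor), the lower of the two numbers known so far; compound 1 `Cc1cccc(C)c1NC(=O)/C=C/C(=O)N1C/C(=C\c2ccccc2)C(=O)/C(=C/c2ccccc2)C1` gives 22000 nM, and the step of a 4.0-fold lower number from compound 1 to compound 2 (0.60 log units; beyond the scatter) is the only one measured. Compound 3 `Cc1ccc(NC(=O)/C=C/C(=O)N2C/C(=C\c3ccccc3)C(=O)/C(=C/c3ccccc3)C2)cc1` carries the change (methyl in place of acetyl on an aromatic carbon). Within the data shown here, no measured step isolates this exact change; the step from compound 1 to compound 2 swaps the whole aryl pattern at once and so bears only loosely on it. Accordingly a modest rise is expected, a 2.0-fold higher number from compound 2 to compound 3 (0.30 log units; within the scatter). Compound 3 is estimated at 11000 nM, within 4000 nM to 30000 nM.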

Compound 3, half-maximal inhibitory concentration: 5800 nM
For compound 3 the middle estimate is 1.9-fold (0.28 log units) above the measured one; the range from low to high includes it.
By their numbers in this assay, from the lowest: compounds 2 and 3 (each within the scatter of the next); then compound 1.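

Replacing acetyl with methyl on the aromatic carbon para to a large group leaves the number within the scatter in this assay, with a 1.1-fold higher number from compound 2 to compound 3 (0.02 log units; within the scatter), so the acetyl carbonyl is not required at this position. The gain over the 2,6-dimethylphenyl pattern also survives without acetyl, with a 3.8-fold lower number from compound 1 to compound 3 (0.58 log units; beyond the scatter). Nothing available explains either step. On these data alone, whether an amine, a carboxylic acid or a longer chain at this position would shift the number remains open, as does whether the 4-substituted pattern alone accounts for the gain.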